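Swapping one aryl group on a shared core

The compounds below may be only part of what the source reports. "The series", "measured", "known", "first", "only" and "open" are said of these compounds alone.

In a functional assay on NCI-H460 cells (Homo sapiens) for antiproliferative activity, read by MTT assay, with a stated time of 48 h (a lower number here means a stronger inhibitor, a higher number a weaker inhibitor), compound 1 `COc1cc(-c2cccc3nc(-c4ccc(C)cc4)oc23)cc(OC)c1OC` gives 1900 nM and compound 3 `COc1cc(-c2nc3cccc(-c4cc(OC)c(OC)c(OC)c4)c3o2)ccc1O` gives 2000 nM. These two stand level, as a 1.1-fold higher number from compound 1 to compound 3 (0.02 log units; within the scatter) shows. Compound 2 `COc1cc(-c2cccc3nc(-c4cccc(C)c4)oc23)cc(OC)c1OC` gives > 25000 nM, which is a limit of the assay and not a number.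

The next compound is compound 4 `COc1cc(-c2cccc3nc(-c4cccc(N)c4)oc23)cc(OC)c1OC`, with 3-aminophenyl in place of 4-hydroxy-3-methoxyphenyl on an aromatic carbon.

Two large steps bear on this change. Replacing 4-methylphenyl with 3-methylphenyl gives an at least 13-fold higher number from compound 1 to compound 2 (1.11 log units; beyond the scatter), and replacing that 3-methylphenyl with 4-hydroxy-3-methoxyphenyl gives an at least 12-fold lower number from compound 2 to compound 3 (1.09 log units; beyond the scatter). Among these three compounds, the two with measured numbers carry a group with a substituent at 4, and compound 2 does not. Compound 4 also lacks one, so it resembles compound 2 in this respect. However, no tested compound carries an amino group, so this comparison is uncertain, and a smaller loss than the one seen for compound 2 seems reasonable.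

The expected change is a 3.0-fold higher number from compound 3 to compound 4 (0.48 log units; beyond the scatter), meaning a weaker inhibitor. For compound 4, the estimated value is 6000 nM, with an expected range of 1200 nM to 25000 nM.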

Compound 4, half-maximal inhibitory concentration: 2600 nM
Compound 4: middle estimate off by 2.3-fold (0.36 log units), on the high side; the measured number falls inside the stated range.
By their numbers in this assay, from the lowest: compounds 1, 3 and 4 (each within the scatter of the next). At a limit, above all of these: compound 2.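

For the compounds shown here, compound 4 shows that a group at 3 on this phenyl ring is compatible with activity, which the earlier compounds could not show. In this assay, the 3-aminophenyl of compound 4 stands level with both earlier active groups, with a 1.3-fold higher number from compound 3 to compound 4 (0.11 log units; within the scatter) and a 1.4-fold higher number from compound 1 to compound 4 (0.14 log units; within the scatter), so a substituent at 4 is not required across these compounds, and compound 2 alone stays out of line with them. The single change of amino in place of methyl on that ring gives an at least 9.6-fold lower number from compound 2 to compound 4 (0.98 log units; beyond the scatter), so the identity of the group at 3 matters, not just its presence, though the value of compound 2, > 25000 nM, is a limit and not a number, which leaves this step only a bound: the limit of > 25000 nM in this assay, at which 1 of the 4 values shown sits.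

The compounds shown leave open whether other groups at 3, such as hydroxyl or methoxy, would behave like the amino group or like the methyl group. They also leave open how a 4-aminophenyl group would compare, which would show whether the amino group is tolerated equally at 4 and at 3.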